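The source may hold more compounds than are shown below. What is called first, only, known or untested is meant among the compounds shown, and "the series" means these compounds.

Compound 1 `CC(=O)Nc1ccc(-c2nc3cc(C(F)(F)F)ccc3n2C)cc1`: in an ADME assay on Vero cells (Chlorocebus sabaeus) for cytotoxicity (a lower number here means that less compound is tolerated, a higher number that more compound is tolerated), compound 1 gives > 100000 nM, which is a limit of the assay rather than a number.
Compound 2 `O=C(O)CCC(=O)Nc1ccc(-c2nc3cc(C(F)(F)F)ccc3[nH]2)cc1`: in this assay compound 2 gives > 100000 nM, again only a limit.
Compound 3 `O=C(CN1CCCCC1)Nc1ccc(-c2nc3cc(Cl)c(Cl)cc3[nH]2)cc1`: in this assay compound 3 gives > 100000 nM, once more a limit.

Compound 2 therefore stands where every measured compound stands, at the limit of > 100000 nM in this assay, at which 3 of the 3 values shown sit; no exact number is known for it. Compound 4 `COc1ccc(-c2nc3cc(C(F)(F)F)ccc3[nH]2)cc1` differs from compound 2 in a single place: methoxy in place of ((2-carboxyethyl)carbonyl)amino on an aromatic carbon. Among the measured compounds shown here, no measured pair differs in one place, so no step between measured compounds can be compared with this change. The expectation is no shift beyond the usual scatter in this assay. Compound 4 is estimated at 100000 nM, within a range from 30000 nM to 300000 nM. This estimate means an expected step of a number no higher from compound 2 to compound 4 (the limit leaves the size open).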

Compound 4, half-maximal cytotoxic concentration: 15000 nM
Compound 4: the middle estimate sits 6.7-fold (0.82 log units) above what was measured, and the stated range ends above it.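

Replacing ((2-carboxyethyl)carbonyl)amino with methoxy on this aromatic carbon gives, in this assay, an at least 6.6-fold lower number from compound 2 to compound 4 (0.82 log units; beyond the scatter), the first sign that this place can change how much compound is tolerated. Among the compounds shown here, compound 4 also gives the only exact number among the values shown. The full size of the step stays open, since compound 2 marks only a limit of the assay: the limit of > 100000 nM in this assay, at which 3 of the 4 values shown sit.

On these data alone, whether the change comes from losing the longer chain or from gaining methoxy remains open. An amine or a hydroxyl group at this carbon could help separate the two.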